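This account rests on a few compounds, and the source may have more. Where it says the series, first, only, none or still open, it means among the compounds named here.

Compound 1 `COc1cc(-c2nn(-c3cccc(NC(=O)c4cccc(C(F)(F)F)c4)c3)cc2-c2ccncc2)ccc1Cl`: > 50000 nM
Compound 2 `COc1cc(-c2nn(-c3cccc(NC(=O)Nc4ccc(Cl)c(Cl)c4)c3)cc2-c2ccncc2)ccc1Cl`: > 50000 nM
Compound 3 `COc1cc(-c2nn(-c3cccc(NC(=O)Nc4cccc(C(F)(F)F)c4)c3)cc2-c2ccncc2)ccc1Cl`: 50000 nM

Three compounds built on one shared core were tested in a functional assay on SW-620 cells (Homo sapiens) for inhibition, read by sulforhodamine B assay, with a stated time of 48 h; a higher number here means that more compound is tolerated, a lower number that less compound is tolerated. Compound 1 reached only a limit of the assay, > 50000 nM. Compound 2 likewise shows only a limit, > 50000 nM. For the measured compounds named here, compound 3 gives the sole actual number, 50000 nM. For compounds 1 and 2 the entries are limits, as the limit of > 50000 nM in this assay, at which 2 of the 3 values shown sit, makes plain. The change to compound 4 `COc1cc(-c2nn(-c3cccc(NC(=O)c4ccc(Cl)c(C(F)(F)F)c4)c3)cc2-c2ccncc2)ccc1Cl` is 4-chloro-3-(trifluoromethyl)phenyl in place of (3-(trifluoromethyl)phenyl)amino on a carbonyl carbon. Going by the values given here, no measured step matches it directly; the nearest is a number no higher from compound 1 to compound 3 (the limit leaves the size open), which runs in the reverse sense, from an aryl amide to a urea, its size hidden by the limit. a step that the two limits leave unreadable from compound 1 to compound 2 and a number no higher from compound 2 to compound 3 (the limit leaves the size open) add nothing readable. Compound 4 is therefore expected to show no change at the digits printed from compound 3 to compound 4 (within the scatter), staying close to the limit. The estimate for compound 4 is 50000 nM, with a range from 20000 nM to 100000 nM.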

Compound 4, concentration lethal to 50% of the cells: > 32500 nM
Compound 4: a limit, no number (the forecaster's own chance of this, stated with the estimate: 70%); the middle value does not contradict the limit.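

Compound 4 gives only a limit, so its steps from compound 1, compound 2 and compound 3 cannot be read. Left open is whether chloro in place of hydrogen, the single change between compound 1 and compound 4, alters the reading at all.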